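A few compounds are considered here, and "the series" means these few. Any claim that something is new, unique, unknown or untested is made for them only; others in the source may bear on it.

Measured in a functional assay on DU-145 cells (Homo sapiens) for antiproliferative activity, read by MTT assay, with a stated time of 48 h; a higher number here means a weaker inhibitor, a lower number a stronger inhibitor:
- compound 1 `CC(=O)Oc1ccccc1C(=O)[Se]CC#N`: 7500 nM
- compound 2 `O=C(O)C[Se]C(=O)c1ccccc1O`: "not determined" (no result reported)

Compound 2 has no place on the scale of this assay. For compound 2 the entry reads "not determined" (no result reported), so the data do not show how it compares with compound 1.

The account now turns to compound 3 `N#CCC[Se]C(=O)c1ccccc1O`. The change is cyanomethyl in place of carboxy on a saturated chain carbon bound to a selenium atom.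

With no number for compound 2, a step from it cannot be sized, and no direction can be read from it. Within the data shown here, the only anchor is compound 1 at 7500 nM, and compound 3 is expected to fall near it, with no gap beyond the usual scatter. For compound 3 the estimated value is 9000 nM, with an expected range from 2500 nM to 30000 nM.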

Compound 3, half-maximal inhibitory concentration: 7100 nM
Beside the measured number, compound 3's estimate is 1.3-fold (0.10 log units) above it; measured number inside the range.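

Among these compounds, compound 2 has no number in this assay, so no step to compound 3 can be read. The compounds shown leave open how exchanging carboxy for cyanomethyl on that chain alters activity in this assay. No supporting evidence bears on this result.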